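Swapping the Aryl on the Hydrazone Carbon: Compound 4

The compounds below may be only part of what the source reports. "The series", "measured", "known", "first", "only" and "open" are said of these compounds alone.

Measured so far in an assay on isolated protein for inhibition of Maltase-glucoamylase (Homo sapiens), with a stated time of 15 min; on this read-out higher numbers stand for weaker inhibition and lower numbers for stronger inhibition:
compound 1, `O=C(N/N=C/c1cccs1)c1ccc(-c2nc3ccccc3s2)cc1`, 8480 nM;
compound 2, `COc1ccc(/C=N/NC(=O)c2ccc(-c3nc4ccccc4s3)cc2)c(O)c1`, 6970 nM;
compound 3, `O=C(N/N=C/c1ccccc1)c1ccc(-c2nc3ccccc3s2)cc1`, 8050 nM.

Compound 1 gives the highest of the three numbers, yet its distance to compound 3 (a 1.1-fold lower number from compound 1 to compound 3 (0.02 log units; within the scatter)) and to compound 2 (a 1.2-fold lower number from compound 1 to compound 2 (0.09 log units; within the scatter)) both fall within the scatter, so the three share the same level. Compound 4, `O=C(N/N=C/c1ccc(Cl)cc1)c1ccc(-c2nc3ccccc3s2)cc1`, differs from compound 1 by 4-chlorophenyl in place of thiophen-2-yl on a carbon with a double bond to nitrogen. The step most like this one, a 1.1-fold lower number from compound 1 to compound 3 (0.02 log units; within the scatter), put a six-membered carbon ring in place of the same thiophen-2-yl and did not move the number beyond the scatter. The expected step of a 1.1-fold lower number from compound 1 to compound 4 (0.05 log units; within the scatter) is therefore none beyond the scatter, and compound 4 is estimated at 7500 nM, between 4000 nM and 15000 nM.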

Compound 4, half-maximal inhibitory concentration: 5310 nM
Beside the measured number, compound 4's estimate is 1.4-fold (0.15 log units) above it, and the stated range covers the measured number.
By their numbers in this assay, from the lowest: compounds 4, 2, 3 and 1 (each within the scatter of the next).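

Putting a chloro group on the phenyl ring tests a substituent on the ring at this position, and it stays within the scatter (a 1.5-fold lower number from compound 3 to compound 4 (0.18 log units; within the scatter)). The 4-chlorophenyl group also stays within the scatter when set against thiophen-2-yl (a 1.6-fold lower number from compound 1 to compound 4 (0.20 log units; within the scatter)) and against 2-hydroxy-4-methoxyphenyl (a 1.3-fold lower number from compound 2 to compound 4 (0.12 log units; within the scatter)), so all four compounds share one level in this assay. No supporting measurement bears on why this position tolerates these swaps.

Going by these compounds, whether a ring carrying an amine or a carboxylic acid, or a longer chain in place of the ring, would shift the number beyond the scatter remains open.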